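A Fluorine Added to the Benzyl Ring of Compound 3

The source may report more compounds than this note shows. Statements on the series, on what has been measured and on what is new or still open speak of the compounds shown alone.

Within the data shown here, in a functional assay on CCRF-CEM cells (Homo sapiens) for cytotoxicity, read by cell counting, with a stated time of 3 days (on this read-out higher numbers stand for weaker inhibition and lower numbers for stronger inhibition), compound 3 `C=C(Br)C(=O)Nc1ccc(/C=C2\SC(=O)N(Cc3ccccc3)C2=O)cc1` gives 2300 nM, the lowest of the three numbers known here. Compound 1 `C=C(Br)C(=O)Nc1ccc(/C=C2\SC(=O)N(Cc3cccc(Cl)c3)C2=O)cc1` gives 3700 nM, and the step of a 1.6-fold lower number from compound 1 to compound 3 (0.21 log units; within the scatter) stays within the scatter. Compound 2 `Nc1ccc(/C=C2\SC(=O)N(Cc3ccccc3)C2=O)cc1` gives 42000 nM, and the step of an 18-fold lower number from compound 2 to compound 3 (1.26 log units; beyond the scatter) is large. Compound 4 `C=C(Br)C(=O)Nc1ccc(/C=C2\SC(=O)N(Cc3ccc(F)cc3)C2=O)cc1` differs from compound 3 in one place: fluoro in place of hydrogen on an aromatic carbon. Among the measured compounds shown here, the only measured step that touches that benzyl ring is a 1.6-fold lower number from compound 1 to compound 3 (0.21 log units; within the scatter), so a halogen on that ring made no difference beyond the scatter. A similar outcome is expected here: the step of a 1.1-fold higher number from compound 3 to compound 4 (0.04 log units; within the scatter) is estimated to stay within the scatter. Compound 4 is therefore expected to give about 2500 nM, with a likely range from 1200 nM to 5000 nM.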

Compound 4, half-maximal inhibitory concentration: 2400 nM
Compound 4: middle estimate off by 1.0-fold (0.02 log units), on the high side; the range from low to high includes it.
By their numbers in this assay, from the lowest: compounds 3, 4 and 1 (each within the scatter of the next); then compound 2.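

Adding fluoro to the benzyl ring leaves the result within the scatter (a 1.0-fold higher number from compound 3 to compound 4 (0.02 log units; within the scatter)). Moving from 3-chlorophenyl to 4-fluorophenyl also stays within the scatter (a 1.5-fold lower number from compound 1 to compound 4 (0.19 log units; within the scatter)), so the unsubstituted benzyl ring and both halogen-bearing rings cannot be told apart in this cell test. Nothing available explains this lack of separation.

On these data alone, whether a methoxy group, an amine or a carboxylic acid at the same ring place would move the number beyond the scatter remains open. So does the effect of replacing the benzyl group with a longer chain.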